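Swapping methyl for 4-fluorophenyl on a carbonyl carbon

The source may hold more compounds than are shown below. What is called first, only, known or untested is meant among the compounds shown, and "the series" means these compounds.

Measured so far in an ADME assay on cells (Hepatocyte, Homo sapiens) for metabolic stability, with a stated time of 30 min (on this read-out lower numbers stand for a less stable compound and higher numbers for a more stable compound), for three compounds:
Compound 1 `O=C(NC1CCC(CN2CCN(c3cc(=O)c4cc(C(F)(F)F)cc([N+](=O)[O-])c4s3)CC2)CC1)c1ccccc1` gives 92.9%
Compound 2 `CC(=O)OC1CCC(CN2CCN(c3cc(=O)c4cc(C(F)(F)F)cc([N+](=O)[O-])c4s3)CC2)CC1` gives 0%
Compound 3 `Nc1cc(C(F)(F)F)cc2c(=O)cc(N3CCN(CC4CCCCC4)CC3)sc12` gives 0.9%

Compound 2 sits level with compound 3, within the usual scatter, and far under compound 1. Compound 4 `O=C(OC1CCC(CN2CCN(c3cc(=O)c4cc(C(F)(F)F)cc([N+](=O)[O-])c4s3)CC2)CC1)c1ccc(F)cc1` differs from compound 2 in one place, with 4-fluorophenyl in place of methyl on a carbonyl carbon. The acetoxy group thus becomes ((4-fluorophenyl)carbonyl)oxy.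

Within the data shown here, the one measured step that bears on this is a number 92.9 percentage points lower from compound 1 to compound 2 (beyond the scatter) when acetoxy replaces benzamido on a saturated ring carbon, a large step beyond the scatter. Compound 4 regains a six-membered aromatic ring, as the benzamido group of compound 1 has, yet it keeps the oxygen of the acetoxy group of compound 2. The measurements do not show whether the ring or the oxygen matters, and compound 3 differs in too many places to help. So only a small rise is expected in this assay on the more stable side, far short of that large step. The expected change is a number 12 percentage points higher from compound 2 to compound 4 (beyond the scatter) in this estimate. For compound 4 the estimated value is 12% and the expected range runs from 0% to 45% at its two ends.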

Compound 4, percent of the compound remaining: 3%
For compound 4 the middle estimate is 9 percentage points above the measured one; the measured number falls inside the stated range.
By their numbers in this assay, from the lowest: compounds 2, 3 and 4 (each within the scatter of the next); then compound 1.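

In this assay, the move to a larger group on this carbonyl carbon gives a number 3 percentage points higher from compound 2 to compound 4 (within the scatter), a step within the usual scatter, so 4-fluorophenyl and methyl cannot be told apart here when the carbonyl is attached through oxygen. The other step, a number 89.9 percentage points lower from compound 1 to compound 4 (beyond the scatter), is large, which shows that a six-membered aromatic ring on the carbonyl carbon does not by itself go with the high number of compound 1. No measurement here explains why these compounds differ in this read-out.

Compound 1 and compound 4 differ both in the link to the saturated ring, with oxygen in one and the amide nitrogen in the other, and in the fluorine on the aromatic ring, so the compounds shown do not separate the two changes. Also open, going by these compounds, is how acetamido, 4-fluorobenzamido or a simple amine on the same saturated ring carbon would read, and the first two would show whether the amide link holds up without the unsubstituted phenyl ring of compound 1.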